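Methylsulfonyl for fluoro on the pendant aryl

The compounds below may be only part of what the source reports. "The series", "measured", "known", "first", "only" and "open" are said of these compounds alone.

Compound 1, `O=C(O)/C=C/c1ccc(/C(=C(/CCCl)c2ccccc2)c2ccc3[nH]ncc3c2)cc1`: 9 nM
Compound 2, `CC/C(=C(/c1ccc(/C=C/C(=O)O)cc1)c1cc(C)c2[nH]ncc2c1)c1ccccc1`: 59 nM
Compound 3, `O=C(O)/C=C/c1ccc(/C(=C(\c2ccc(F)cc2Cl)C2CCC2)c2ccc3[nH]nc(F)c3c2)cc1`: 2 nM

In a functional assay on MCF7 cells (Homo sapiens) for cytotoxicity, read by CellTiter-Glo, with a stated time of 5 days (a lower number here means a stronger inhibitor, a higher number a weaker inhibitor), compound 3 gives the lowest number of the three measured compounds. Compound 1 stands nearest to it, and compound 2 furthest, and both gaps lie beyond the usual scatter, so compound 3 is the strongest of the three in this assay. Among the compounds with values here, none of the measured pairs differs in a single place, so no single step has been measured directly.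

Compound 4, `CS(=O)(=O)c1ccc(/C(=C(\c2ccc(/C=C/C(=O)O)cc2)c2ccc3[nH]nc(F)c3c2)C2CCC2)c(Cl)c1`, has not yet been measured in this assay. It differs from compound 3 in one place: methylsulfonyl in place of fluoro on an aromatic carbon. Within the data shown here, nothing among the measured compounds tests an exchange of this kind. A modest loss of potency in this assay, or no change beyond the scatter, is expected for compound 4; the step from compound 3 to compound 4 is estimated as a 2.5-fold higher number from compound 3 to compound 4 (0.40 log units; beyond the scatter). Compound 4 is expected to give about 5 nM, within a range from 1.5 nM to 20 nM.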

Compound 4, half-maximal inhibitory concentration: 2.3 nM
For compound 4 the middle estimate is 2.2-fold (0.34 log units) above the measured one; measured number inside the range.
By their numbers in this assay, from the lowest: compounds 3 and 4 (each within the scatter of the next); then compound 1; then compound 2.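

In this assay, placing methylsulfonyl on the aromatic carbon that is meta to a chloro group and para to a large group, where compound 3 has fluoro, gives a 1.2-fold higher number from compound 3 to compound 4 (0.06 log units; within the scatter) and is the only step shown between compounds that differ in one place. At this position, with the rest of the structure unchanged, a group of 4 heavy atoms and 2 hydrogen-bond acceptors can therefore stand in for a single fluorine without a difference beyond the scatter. No measurement shown accounts for this result. As far as these compounds go, whether an amine, a carboxylic acid or a longer chain at the same carbon would read alike remains open. From the compounds shown here alone, it also remains open whether methylsulfonyl would read the same way without the chloro group or on the cores of compound 1 and compound 2.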